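The compounds below may be only part of what the source reports. "The series", "measured", "known", "first", "only" and "open" are said of these compounds alone.

For the measured compounds named here, compound 2 `O=C(Nc1ccc(Cl)c(Cl)c1)Nc1nnc(Sc2ncnc3scc(-c4ccncc4)c23)s1` gives 61900 nM in a functional assay on HepG2 cells (Homo sapiens) for antiproliferative activity, read by MTT assay, with a stated time of 48 h (a higher number here means a weaker inhibitor, a lower number a stronger inhibitor), one of only two numbers measured, and compound 1 `Cc1ccc(NC(=O)Nc2nnc(Sc3ncnc4scc(-c5ccncc5)c34)s2)cc1` gives 52000 nM, within the scatter of that, since the single measured step, a 1.2-fold higher number from compound 1 to compound 2 (0.08 log units; within the scatter), changed almost nothing. Compound 3 `O=C(Nc1ccc(Cl)c(C(F)(F)F)c1)Nc1nnc(Sc2ncnc3scc(-c4ccncc4)c23)s1` differs from compound 2 by trifluoromethyl in place of chloro on an aromatic carbon. Going by the values given here, only that one small step offers any guidance, so no movement beyond the scatter is expected in this assay from this change. Compound 3 is therefore estimated at 60000 nM, with a likely range from 25000 nM to 150000 nM. That estimate means a step of a 1.0-fold lower number from compound 2 to compound 3 (0.01 log units; within the scatter).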

Compound 3, half-maximal inhibitory concentration: 45300 nM
Beside the measured number, compound 3's estimate is 1.3-fold (0.12 log units) above it, within the range that was stated.
By their numbers in this assay, from the lowest: compounds 3, 1 and 2 (each within the scatter of the next).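

In this assay trifluoromethyl in place of chloro, on an aromatic carbon ortho to a chloro group, moves nothing beyond the scatter (a 1.4-fold lower number from compound 2 to compound 3 (0.14 log units; within the scatter)). Changing the whole aryl group also stays within it (a 1.1-fold lower number from compound 1 to compound 3 (0.06 log units; within the scatter)), so all three substituted phenyl groups on this amide-type nitrogen now read alike. No measurement here gives a reason for this flat response. As far as these compounds go, whether any change on this phenyl ring can shift the number remains open. An amine or a carboxylic acid at this position, or a longer chain replacing the phenyl ring, could test that.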